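Stability of compound 4 in liver microsomes: an estimate

The compounds below may be only part of what the source reports. "The series", "measured", "known", "first", "only" and "open" are said of these compounds alone.

Compound 1 `CCC[C@]1(C(=O)N2CC[C@](c3ccc(C(F)(C(F)(F)F)C(F)(F)F)cc3)(S(=O)(=O)c3ccc(F)cc3)C2)CC[C@H](C(=O)O)CC1` gives "not determined" (no result reported)
Compound 2 `CO[C@]1(C(=O)N2CC[C@](c3ccc(C(F)(C(F)(F)F)C(F)(F)F)cc3)(S(=O)(=O)c3ccc(F)cc3)C2)CC[C@H](C(=O)O)CC1` gives 95%
Compound 3 `O=C(N1CC[C@](c2ccc(C(F)(C(F)(F)F)C(F)(F)F)cc2)(S(=O)(=O)c2ccc(F)cc2)C1)C12CCC(C(=O)O)(CC1)OC2` gives "not determined" (no result reported)

These three entries come from an ADME assay on microsomes from liver (Mus musculus) for metabolic stability, with a stated time of 10 min (a lower number here means that less of the compound is left, a higher number that more of the compound is left), and only one of them is a number. Compound 3 has no single value to stand on (its entry reads "not determined" (no result reported)), and compound 1 shares that gap. Going by the values given here, the sole reference is therefore compound 2 (95%), which sets a high mark on this scale.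

The next compound is compound 4 (`O=C([C@H]1CC[C@H](CO)CC1)N1CC[C@](c2ccc(C(F)(C(F)(F)F)C(F)(F)F)cc2)(S(=O)(=O)c2ccc(F)cc2)C1`). The change from compound 3 is a group of 8 heavy atoms (7 carbon, 1 oxygen; one six-membered non-aromatic ring of carbon only) in place of a group of 11 heavy atoms (8 carbon, 3 oxygen; one six-membered non-aromatic ring of carbon only, one six-membered non-aromatic ring with 1 hetero atom), on a carbonyl carbon and the group that enters is 4-(hydroxymethyl)cyclohexyl, on a carbonyl carbon.

Among the compounds with values here, no measured step exists to size this change, so any expectation here is loose. If compound 3 sat near compound 2 (95%), a moderate step downward would be expected in this assay on going to compound 4. The expected value for compound 4 (75%) has an estimated range from 45% to 98% and rests on a single number.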

Compound 4, percent of the compound remaining: 63%
Estimate against measurement, compound 4: 12 percentage points above, and the stated range covers the measured number.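

In this assay, the group on the carbonyl carbon now has a measured effect: with the rest of the molecule unchanged, 4-(hydroxymethyl)cyclohexyl in place of 4-carboxy-1-methoxycyclohexyl gives a number 32 percentage points lower from compound 2 to compound 4 (beyond the scatter) in a single swap. This place therefore responds to what sits on it, something a lone earlier number could not show. Nothing measured here accounts for the drop.

Steps involving compound 1 or compound 3 cannot be read, as neither has a number. From the compounds shown here alone, the swap also removes both the methoxy and the carboxylic acid at once, so which of them matters stays open, as does how an amine or a longer chain in place of the hydroxymethyl would fare.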